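The compounds below may be only part of what the source reports. "The series", "measured", "known", "first", "only" and "open" are said of these compounds alone.

Measured compounds:
- compound 1, `CCOC(=O)c1cnc(C(C)(C)C)nc1NN1C(=O)C=C(C)C1=O`, in a functional assay on Jurkat cells for inhibition of nuclear factor NF-kappa-B complex (Homo sapiens) (on this read-out lower numbers stand for stronger inhibition and higher numbers for weaker inhibition), gives 1000 nM
- compound 2, `CCOC(=O)c1cnc(-n2nc(C)cc2C)nc1NN1C(=O)C=C(C)C1=O`, in this assay gives 10000 nM
- compound 3, `CCOC(=O)c1cnc(-c2cccc(OC)c2)nc1NN1C(=O)C=C(C)C1=O`, in this assay gives 5000 nM

Compound 1 stands lowest of the three and is the strongest inhibitor of the set, since its steps to both other compounds lie beyond the scatter: a 10-fold higher number from compound 1 to compound 2 (1.00 log units; beyond the scatter) and a 5.0-fold higher number from compound 1 to compound 3 (0.70 log units; beyond the scatter). Compound 4, `CCOC(=O)c1cnc(-c2ccc(Cl)cc2)nc1NN1C(=O)C=C(C)C1=O`, has not yet been measured in this assay. Its change from compound 1 is 4-chlorophenyl in place of tert-butyl on an aromatic carbon. Both measured steps from compound 1 bear on this change, as each replaced the tert-butyl group with an aromatic ring and each raised the number, by a modest amount. The 4-chlorophenyl group in compound 4 is, like the 3-methoxyphenyl group of compound 3, a six-membered aromatic ring of carbon only, so the step from compound 1 to compound 3 is the closer guide. A modest rise in this assay is therefore expected for compound 4, on the order of a 5.0-fold higher number from compound 1 to compound 4 (0.70 log units; beyond the scatter). Compound 4 is estimated at 5000 nM, with a range from 1500 nM to 15000 nM.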

Compound 4, half-maximal inhibitory concentration: 300 nM
Estimate against measurement, compound 4: 17-fold (1.22 log units) above, and the stated range ends above it.
By their numbers in this assay, from the lowest: compound 4; then compound 1; then compounds 3 and 2 (each within the scatter of the next).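

At this position, on the aromatic carbon between two ring nitrogen atoms, replacing tert-butyl with an aromatic ring does not always raise the number in this assay: 4-chlorophenyl gives a 3.3-fold lower number from compound 1 to compound 4 (0.52 log units; beyond the scatter), and compound 4 is the strongest inhibitor of the four. The presence of an aromatic ring therefore does not by itself set the number, as 4-chlorophenyl gives a 17-fold lower number from compound 3 to compound 4 (1.22 log units; beyond the scatter) against 3-methoxyphenyl and a 33-fold lower number from compound 2 to compound 4 (1.52 log units; beyond the scatter) against 3,5-dimethyl-1H-pyrazol-1-yl. No measurement available here accounts for these differences.

Compounds 3 and 4 differ in both the substituent on the phenyl ring and its place, so the contribution of each remains unresolved. From the compounds shown here alone, how an unsubstituted phenyl, a 3-chlorophenyl or a 4-methoxyphenyl group, or a phenyl ring carrying an amine or a carboxylic acid, would stand at this position also remains open.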